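The source may report more compounds than this note shows. Statements on the series, on what has been measured and on what is new or still open speak of the compounds shown alone.

Compound 1 `CC(O)(CSc1cc(C(F)(F)F)cc(C(F)(F)F)c1)C(=O)Nc1cccc(S(F)(F)(F)(F)F)c1` and compound 2 `CC(O)(COc1ccc(S(F)(F)(F)(F)F)cc1)C(=O)Nc1cc(C(F)(F)F)cc(C(F)(F)F)c1` have cores whose difference is not broken down here. In a functional assay on LNCaP cells (Homo sapiens) for antiproliferative activity, read by propidium iodide staining, with a stated time of 96 h (a lower number here means a stronger inhibitor, a higher number a weaker inhibitor), compound 1 gives 4800 nM and compound 2 gives 1900 nM. Compound 3 `CC(O)(COc1ccc(C(F)(F)C(F)(F)F)cc1)C(=O)Nc1cc(C(F)(F)F)cc(C(F)(F)F)c1` differs from compound 2 by a group of 7 heavy atoms (2 carbon, 5 fluorine; no ring) in place of a group of 6 heavy atoms (5 fluorine, 1 sulfur; no ring), on an aromatic carbon, and in this assay compound 3 gives 2700 nM; this change made a 1.4-fold higher number from compound 2 to compound 3 (0.15 log units; within the scatter). Compound 4 `CC(O)(CSc1cc(C(F)(F)F)cc(C(F)(F)F)c1)C(=O)Nc1cccc(C(F)(F)C(F)(F)F)c1` differs from compound 1 by a group of 7 heavy atoms (2 carbon, 5 fluorine; no ring) in place of a group of 6 heavy atoms (5 fluorine, 1 sulfur; no ring), on an aromatic carbon, the same kind of change, though here the place is meta to a large group rather than para to a large group. A similarly small step is expected, a 1.4-fold higher number from compound 1 to compound 4 (0.13 log units; within the scatter). Going by the values given here, this expectation rests on compound 1 with 4800 nM and on a 1.4-fold higher number from compound 2 to compound 3 (0.15 log units; within the scatter), the one measured instance of this change. Compound 4 is therefore estimated at 6500 nM, expected to fall between 3000 nM and 14000 nM.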

Compound 4, half-maximal inhibitory concentration: 3900 nM
Compound 4: middle estimate off by 1.7-fold (0.22 log units), on the high side, and the stated range covers the measured number.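

Putting 1,1,2,2,2-pentafluoroethyl in place of the group of five fluorines and one sulfur gives a 1.2-fold lower number from compound 1 to compound 4 (0.09 log units; within the scatter) in this assay. Set beside the earlier instance, the two cores show no real difference in how this change plays out: the same change on two cores in this assay, a 1.4-fold higher number (0.15 log units; within the scatter) from compound 2 to compound 3 and a 1.2-fold lower number (0.09 log units; within the scatter) from compound 1 to compound 4, 1.7-fold (0.24 log units) apart, within the scatter of two such steps. So in these two pairs the swap leaves the number essentially where it was, but two pairs cannot show that this holds on other cores, or that the two groups are interchangeable in general.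

The compounds shown leave open whether a quite different group at the same place, such as a nitrile, an amine or a longer fluorinated chain, would shift the number beyond the scatter. They also leave open how this swap behaves in other assays.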